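This account rests on a few compounds, and the source may have more. Where it says the series, first, only, none or still open, it means among the compounds named here.

The measured compounds and their values:

- compound 1, `CC(C)(C)C(=O)OCO[P@@]1(=O)OCC(C)(C)[C@H](C(=O)NCCC(=O)O)O1`, which in an ADME assay on blood (Homo sapiens) for pharmacokinetics (on this read-out higher numbers stand for a longer-lived compound and lower numbers for a shorter-lived compound), gives only the limit > 1 h.
- compound 2, `COC(=O)CCNC(=O)[C@@H]1O[P@](=O)(OCOC(=O)c2ccnn2C)OCC1(C)C`, which in this assay gives only the limit < 0.16 h.
- compound 3, `COC(=O)CCNC(=O)[C@@H]1O[P@@](=O)(OCOC(=O)c2ccns2)OCC1(C)C`, which in this assay gives only the limit < 0.16 h.

Among the measured compounds shown here, compound 1 therefore stands at the limit of > 1 h in this assay, at which 1 of the 3 values shown sits, while the other two values sit at the limit of < 0.16 h in this assay, at which 2 of the 3 values shown sit; no measured number is known for any of the three, and no two of them differ in a single place, so no step between measured compounds can be read off.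

Compound 4, `CC(C)(C)C(=O)OCO[P@@]1(=O)OCC(C)(C)[C@H](C(=O)NCCC(=O)OCCS(C)(=O)=O)O1`, differs from compound 1 by 2-(methylsulfonyl)ethyl in place of hydrogen on an oxygen next to a carbonyl group. For the measured compounds named here, with no comparable step in hand, the direction of the change can only be guessed from the values themselves: compound 2 and compound 3, both carrying an ester in place of the free acid, sit at the short-lived limit. The step from compound 1 to compound 4 is therefore expected to run toward a shorter half-life, by about an at least 2.5-fold lower number from compound 1 to compound 4 (0.39 log units; beyond the scatter), which is beyond the usual scatter. Compound 4 is estimated at 0.4 h, with a likely range from 0.1 h to 1.5 h.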

Compound 4, half-life: < 0.16 h
Compound 4 ended at the assay's limit; the forecaster's own chance of this, stated with the estimate: 50%; at least 2.5-fold (0.39 log units) between middle value and limit.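

In this assay, among the compounds shown here, 2-(methylsulfonyl)ethyl in place of hydrogen on an oxygen next to a carbonyl group gives an at least 6.2-fold lower number from compound 1 to compound 4 (0.79 log units; beyond the scatter), the first step in which a single change can be read. With the rest of compound 1 unchanged, going from carboxy to (2-(methylsulfonyl)ethoxy)carbonyl is enough to cross from one limit of the read-out to the other. Compound 4 now stands with the short-lived compounds, and the free acid alone holds the other end: the limit of > 1 h in this assay, at which 1 of the 4 values shown sits.

The compounds shown leave open whether a methyl ester or a primary amide at this place would fall as far as the 2-(methylsulfonyl)ethyl ester does. On these data alone, every value shown is a limit, so the actual half-lives of all four compounds also remain open.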